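The compounds below may be only part of what the source reports. "The series", "measured", "known", "first", "only" and "open" are said of these compounds alone.

Measured so far in a functional assay on SMMC-7721 cells (Homo sapiens) for antiproliferative activity, read by MTT assay, with a stated time of 72 h; on this read-out higher numbers stand for weaker inhibition and lower numbers for stronger inhibition:
- compound 1 `Oc1ccc(Cl)cc1/C=N/NC(=S)N1CCOCC1`: 35300 nM
- compound 2 `Oc1ccccc1/C=N/NC(=S)Nc1ccccc1`: 34100 nM
- compound 3 `C/C(=N\NC(=S)N1CCOCC1)c1ccccc1`: > 64000 nM (a limit)

Compound 3 gives > 64000 nM in this assay, and this is a limit, not a number. Among the compounds with values here, it is the only one of the three compounds without a numerical value. Compound 4 `C/C(=N\NC(=S)N1CCOCC1)c1ccccc1O` differs from compound 3 by hydroxy in place of hydrogen on an aromatic carbon, ortho to a large group.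

Within the data shown here, no two measured compounds differ in one place only, so any expectation rests on indirect comparison. Compound 1 carries a hydroxy on its aromatic ring and gives 35300 nM. Compound 2 also carries one and gives 34100 nM, within the usual scatter of the value for compound 1. Both differ from compound 3 in other places too. A modest move towards stronger inhibition is therefore expected, bringing compound 4 into the range of those two values. The expected change is an at least 2.2-fold lower number from compound 3 to compound 4 (0.35 log units; beyond the scatter). For compound 4 the estimate is 28000 nM, with an expected range from 10000 nM to 60000 nM.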

Compound 4, half-maximal inhibitory concentration: > 64000 nM
Compound 4: only a limit was reported (the forecaster's own chance of this, stated with the estimate: 20%); middle value at least 2.2-fold (0.35 log units) away from the limit.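

Compound 3 and compound 4 are both reported in this assay only as the same limit, not as numbers, so no step can be read between them: the limit of > 64000 nM in this assay, at which 2 of the 4 values shown sit.

The compounds shown leave open whether hydroxy in place of hydrogen on an aromatic carbon changes inhibition at all.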